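The compounds below may be only part of what the source reports. "The series", "measured", "known", "first", "only" and "open" are said of these compounds alone.

Of the compounds shown here, two have so far been tested in an in vitro assay on B300-19 cells for displacement of a labelled ligand from C-C chemokine receptor type 4 (Homo sapiens), tested at 1 uM; on this read-out higher numbers stand for more inhibition at the one concentration tested (going by the name of the read-out) and lower numbers for less inhibition. Compound 1 has the structure `COc1cc2nc(NCc3ccccc3)nc(NC3CCCCCC3)c2cc1OC`, and compound 2 has the structure `COc1cc2nc(N3CCC(N4CCCC4)CC3)nc(N(C)C)c2cc1OC`. In this assay compound 1 gives < 0%, which is a limit of the assay rather than a number. In this assay compound 2 likewise gives < 0%, again a limit of the assay and not a number. Compound 2 therefore stands at the floor of the values shown, and the limit of < 0% in this assay, at which 2 of the 2 values shown sit, shows that every value known here sits at that same floor.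

Compound 3, with the structure `COc1cc2nc(N3CCC(N4CCCC4)CC3)nc(N3CCCCC3)c2cc1OC`, differs from compound 2 in one place: piperidin-1-yl in place of dimethylamino on an aromatic carbon. Within the data shown here, no step between measured compounds exists to show what such a change does, and with both known values at the limit, no move beyond the scatter in this assay is expected. Compound 3 is estimated to give 5%, in a range from -10% to 25%. The expected step of a number at least 5 percentage points higher from compound 2 to compound 3 (that floor lies within the scatter) is thus within the scatter.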

Compound 3, a percentage reported as inhibition, at one concentration (the size of the read-out at that concentration, not a potency): 19%
The estimate for compound 3 lay 14 percentage points below the measured number, within the range that was stated.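

In this assay, putting piperidin-1-yl in place of dimethylamino on this aromatic carbon, next to the ring nitrogen, gives a number at least 19 percentage points higher from compound 2 to compound 3 (beyond the scatter). With the rest of the molecule unchanged, this shows that the group at this position can move the read-out away from the floor, which two compounds sitting at the same limit could not show. On these data alone, the full size of the step stays unknown, because compound 2 is reported only as a limit of the assay: the limit of < 0% in this assay, at which 2 of the 3 values shown sit.

This single pair cannot separate the presence of a ring from the larger number of atoms in the entering group, and diethylamino, an open-chain group, or pyrrolidin-1-yl, a smaller ring, at the same place would help to tell these apart. A reading at one concentration also leaves the potency of compound 3 open.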